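Phenyl in Place of Isopropyl on the Ring Nitrogen

The compounds below may be only part of what the source reports. "The series", "measured", "known", "first", "only" and "open" are said of these compounds alone.

Three compounds sharing one core have been tested in a functional assay on the whole organism (strain Kunming) with Mus musculus as the target, in the maximal electroshock model, with a stated time of 4 h; a higher number here means that more compound is needed for the effect, a lower number that less compound is needed:

compound 1 `O=C1NC2(CC2c2ccc3cccc(OCc4ccccc4)c3n2)C(=O)N1c1ccc([N+](=O)[O-])cc1` gives 300 mg/kg
compound 2 `CCC(CO)N1C(=O)NC2(CC2c2ccc3cccc(OCc4ccccc4)c3n2)C1=O` gives 30 mg/kg
compound 3 `CC(C)N1C(=O)NC2(CC2c2ccc3cccc(OCc4ccccc4)c3n2)C1=O` gives 100 mg/kg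

Compound 3 holds the second highest of these three numbers. Its nearest neighbour is compound 1: a 3.0-fold lower number from compound 1 to compound 3 (0.48 log units; beyond the scatter). Its furthest neighbour is compound 2: a 3.3-fold higher number from compound 2 to compound 3 (0.52 log units; beyond the scatter). The remaining pair shows the widest spread of the set: a 10-fold lower number from compound 1 to compound 2 (1.00 log units; beyond the scatter).

Compound 4 `O=C1NC2(CC2c2ccc3cccc(OCc4ccccc4)c3n2)C(=O)N1c1ccccc1` is the next compound to be measured in this assay. It differs from compound 3 in one place: phenyl in place of isopropyl on an amide-type nitrogen in a ring.

Within the data shown here, no measured step swaps isopropyl for phenyl directly, so the expectation rests on the neighbouring changes. Among the measured compounds shown here, the only compound that carries an aromatic ring on that nitrogen, compound 1, gives the highest number of the three, and the step to isopropyl lowered the number: a 3.0-fold lower number from compound 1 to compound 3 (0.48 log units; beyond the scatter). Compound 4 carries a phenyl without the nitro group, so it is expected to sit between compound 3 and compound 1, with a modest rise rather than a large one.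

Compound 4 is therefore estimated at 200 mg/kg in this assay, with a range from 100 mg/kg to 400 mg/kg. This estimate means an expected step of a 2.0-fold higher number from compound 3 to compound 4 (0.30 log units; within the scatter).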

Compound 4, minimum effective dose: 300 mg/kg
Compound 4: middle estimate off by 1.5-fold (0.18 log units), on the low side, within the range that was stated.
By their numbers in this assay, from the lowest: compound 2; then compound 3; then compounds 1 and 4 (each within the scatter of the next).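

In this assay, among these compounds, hydrogen in place of nitro on the aromatic ring leaves the two compounds level, no change at the digits printed from compound 1 to compound 4 (within the scatter), so the nitro group, the one feature that set compound 1 apart from a plain phenyl, makes no visible difference to this number. The high number therefore goes with the aromatic ring on the ring nitrogen whether or not nitro is present, as phenyl in place of isopropyl gives a 3.0-fold higher number from compound 3 to compound 4 (0.48 log units; beyond the scatter), and phenyl in place of 1-(hydroxymethyl)propyl gives a larger step, a 10-fold higher number from compound 2 to compound 4 (1.00 log units; beyond the scatter). No measurement here explains why an aromatic ring at this nitrogen goes with a need for more compound.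

The compounds shown leave open how other groups on the phenyl ring would behave, such as a methoxy or an amine, and whether a benzyl group, with one carbon separating the aromatic ring from the nitrogen, would read like phenyl or like isopropyl. They also cannot separate the hydroxyl of compound 2 from its longer carbon chain, which a plain sec-butyl group at the same nitrogen would do.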